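The source may hold more compounds than are shown below. What is called first, only, known or untested is meant among the compounds shown, and "the series" means these compounds.

Of the compounds shown here, two with a shared core have been tested so far in a functional assay on U-87MG ATCC cells for antiproliferative activity against U-87 MG (Homo sapiens), read by MTT assay, with a stated time of 48 h; on this read-out lower numbers stand for stronger inhibition and higher numbers for weaker inhibition. There, compound 1 (`COc1cccc(-c2nc(SCC(=O)c3sc(-c4ccccc4)nc3C)[nH]c(=O)c2C#N)c1`) gives 59700 nM and compound 2 (`Cc1nc(-c2ccc(Cl)cc2)sc1C(=O)CSc1nc(-c2cccc(Cl)c2)c(C#N)c(=O)[nH]1`) gives 40100 nM and these two values lie within the usual scatter of each other, so compound 2 cannot be ranked apart from compound 1. The next compound to test is compound 3 (`COc1cccc(-c2nc(SCC(=O)c3sc(-c4ccc(Cl)cc4)nc3C)[nH]c(=O)c2C#N)c1`). It keeps all of compound 2 except for one change (methoxy in place of chloro on an aromatic carbon) in which methoxy takes the place of chloro on an aromatic carbon. Compound 1 also carries the 3-methoxyphenyl group and gives 59700 nM without leaving the scatter around compound 2, so no clear step in either direction is expected. The expected result in this assay is a 1.1-fold higher number from compound 2 to compound 3 (0.05 log units; within the scatter) and that stays within the scatter. Compound 3 is estimated at 45000 nM (range from 20000 nM to 100000 nM).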

Compound 3, half-maximal inhibitory concentration: 41000 nM
For compound 3 the middle estimate is 1.1-fold (0.04 log units) above the measured one, within the range that was stated.
By their numbers in this assay, from the lowest: compounds 2, 3 and 1 (each within the scatter of the next).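

In this assay, replacing 3-chlorophenyl with 3-methoxyphenyl gives a 1.0-fold higher number from compound 2 to compound 3 (0.01 log units; within the scatter), so at this position, meta to a large group, chloro and methoxy cannot be told apart, even though methoxy brings a hydrogen-bond acceptor that chloro lacks. Among these compounds, compound 3 also provides the first single-place comparison with compound 1, chloro in place of hydrogen on an aromatic carbon, and this gives a 1.5-fold lower number from compound 1 to compound 3 (0.16 log units; within the scatter), so that change cannot be read as a gain or a loss either. No supporting evidence bears on these results.

From the compounds shown here alone, whether a different kind of group at this position, such as an amine or a carboxylic acid, would move the number beyond the scatter remains open. The three compounds also leave open whether a longer chain there would do so.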